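Cyclopentylmethyl in place of a branched alkyl ether

A few compounds are considered here, and "the series" means these few. Any claim that something is new, unique, unknown or untested is made for them only; others in the source may bear on it.

Compound 1 `COCCOCCOc1cccc2ccc(N)nc12`: in an assay on cells with melanin-concentrating hormone receptor 1 (Homo sapiens) as the target, read by radioligand binding (on this read-out higher numbers stand for weaker inhibition and lower numbers for stronger inhibition), compound 1 gives > 2000 nM, which is a limit of the assay.
Compound 2 `CCOCC(C)Oc1cccc2ccc(N)nc12`: in this assay compound 2 gives 1070 nM.
Compound 3 `CC(C)C(C)Oc1cccc2ccc(N)nc12`: in this assay compound 3 gives 199 nM.

Compound 3 stands lowest of the two numbers shown, and the only measured step, a 5.4-fold lower number from compound 2 to compound 3 (0.73 log units; beyond the scatter), lies beyond the scatter. The remaining value, that of compound 1, is a limit (the limit of > 2000 nM in this assay, at which 1 of the 3 values shown sits). Compound 4 `Nc1ccc2cccc(OCC3CCCC3)c2n1` differs from compound 3 by cyclopentylmethyl in place of 1,2-dimethylpropyl on an oxygen on an aromatic ring. The measured step replaced ethoxymethyl with isopropyl; the present change exchanges one group of carbon only for another of carbon only and nearly the same size, so no step beyond the scatter is expected in this assay. Compound 4 is therefore estimated at 150 nM, between 50 nM and 450 nM, an expected step of a 1.3-fold lower number from compound 3 to compound 4 (0.12 log units; within the scatter).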

Compound 4, half-maximal inhibitory concentration: 53 nM
The estimate for compound 4 lay 2.8-fold (0.45 log units) above the measured number; low and high end bracket the measured number.
By their numbers in this assay, from the lowest: compound 4; then compound 3; then compound 2. At a limit, above all of these: compound 1.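

Even with carbon-only groups on this oxygen, the group still matters: cyclopentylmethyl gives a 3.8-fold lower number from compound 3 to compound 4 (0.57 log units; beyond the scatter) in this assay, so the number here responds to more than the loss of the ether oxygen. Measured against the ethoxymethyl-bearing chain, the same group gives a 20-fold lower number from compound 2 to compound 4 (1.31 log units; beyond the scatter). The step of an at least 37-fold lower number from compound 1 to compound 4 (1.57 log units; beyond the scatter) starts from a limit of the assay and is a bound only: the limit of > 2000 nM in this assay, at which 1 of the 4 values shown sits.

The compounds shown leave open whether the ring or the additional carbon carries the step from 1,2-dimethylpropyl to cyclopentylmethyl. An open hexyl chain would separate the two, and cyclobutylmethyl or cyclohexylmethyl would show how far ring size matters.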